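Sulfonyl aryl swap in a pyrimidine sulfonamide series

This account rests on a few compounds, and the source may have more. Where it says the series, first, only, none or still open, it means among the compounds named here.

Of the compounds shown here, two have numbers so far. In an assay on cells (Endothelial cell) for binding affinity to Endothelin-1 receptor (Sus scrofa) (a lower number here means a stronger inhibitor, a higher number a weaker inhibitor), compound 1 `COc1cccc(Oc2c(NS(=O)(=O)c3ccc(C(C)(C)C)cc3)ncnc2OCCOc2ncccn2)c1` gives 1.9 nM. Compound 2 `Cc1ccc(-c2c(NS(=O)(=O)c3ccc(Br)cc3)ncnc2OCCOc2ncc(Br)cn2)cc1` gives 2.8 nM in this assay; the two numbers sit within the scatter of each other, so nothing separates compound 2 from compound 1 on this read-out.

Compound 3 `Cc1ccc(-c2c(NS(=O)(=O)c3cccs3)ncnc2OCCOc2ncc(Br)cn2)cc1` is the next member to be measured. It differs from compound 2 in one place: thiophen-2-yl in place of 4-bromophenyl on a sulfonyl sulfur. For the measured compounds named here, no measured pair shows this kind of change on the sulfonyl sulfur, so there is no step to lean on. Both measured compounds carry a six-membered aromatic ring on that sulfur and both sit at low numbers, which is the only footing for an expectation.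

Compound 3 is expected to give about 4.5 nM in this assay, a step of a 1.6-fold higher number from compound 2 to compound 3 (0.21 log units; within the scatter) that may not exceed the scatter, with a range from 1.5 nM to 14 nM.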

Compound 3, half-maximal inhibitory concentration: 3.1 nM
Compound 3: the middle estimate sits 1.5-fold (0.16 log units) above what was measured; measured number inside the range.
By their numbers in this assay, from the lowest: compounds 1, 2 and 3 (each within the scatter of the next).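

On the sulfonyl sulfur, thiophen-2-yl in place of 4-bromophenyl gives a 1.1-fold higher number from compound 2 to compound 3 (0.04 log units; within the scatter) in this assay and so leaves the two compounds unseparated. For the compounds shown here, this is the first single-place step at this position, and it shows that a five-membered aromatic ring with one hetero atom reads the same here as a six-membered aromatic ring of carbon only, with the bromine gone, though the finding rests on this one pair. No measured information bears on why the two groups read alike.

Still open, going by these compounds, is whether the position keeps these low numbers with a non-aromatic group such as cyclohexyl, or with a carboxylic acid or an amine on the aryl ring. On these data alone, it is also open whether thiophen-2-yl behaves the same way on the core of compound 1.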